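Swapping an aryl for a benzyl on the piperazine nitrogen

This account rests on a few compounds, and the source may have more. Where it says the series, first, only, none or still open, it means among the compounds named here.

Compound 1 `O=C1NC(c2ccccc2)(c2ccccc2)C(=O)N1CN1CCN(c2cccc(Cl)c2)CC1` gives 100 mg/kg in a functional assay on the whole organism (strain CD1) with Mus musculus as the target, in the maximal electroshock model, with a stated time of 4 h; a higher number here means that more compound is needed for the effect, a lower number that less compound is needed. Compound 2 `O=C1NC(c2ccccc2)(c2ccccc2)C(=O)N1CN1CCN(c2ccc(F)cc2)CC1` gives 100 mg/kg, and compound 3 `CN1CCN(CN2C(=O)NC(c3ccccc3)(c3ccccc3)C2=O)CC1` gives 10 mg/kg. Compound 1 stands level with compound 2, and together they show the highest numbers of the three, while compound 3 shows the lowest. The step of no change at the digits printed from compound 1 to compound 2 (within the scatter) and the step of a 10-fold lower number from compound 1 to compound 3 (1.00 log units; beyond the scatter) frame the change to compound 4 `O=C1NC(c2ccccc2)(c2ccccc2)C(=O)N1CN1CCN(Cc2ccccc2)CC1`, which differs from compound 1 by benzyl in place of 3-chlorophenyl on an amine nitrogen in a ring. Among the measured compounds shown here, no measured compound carries a benzyl, so this change sits between the 3-chlorophenyl and 4-fluorophenyl of compounds 1 and 2 and the methyl of compound 3. A step toward a lower number, smaller than a 10-fold lower number from compound 1 to compound 3 (1.00 log units; beyond the scatter), is therefore expected. Compound 4 is estimated at 30 mg/kg, with a range from 10 mg/kg to 100 mg/kg, which is expected to mean a step of a 3.3-fold lower number from compound 1 to compound 4 (0.52 log units; beyond the scatter).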

Compound 4, minimum effective dose: 100 mg/kg
Compound 4: middle estimate off by 3.3-fold (0.52 log units), on the low side, and the stated range covers the measured number.
By their numbers in this assay, from the lowest: compound 3; then compounds 1, 2 and 4 (each within the scatter of the next).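

In this assay, moving the aromatic ring onto a saturated chain carbon changes little: no change at the digits printed from compound 1 to compound 4 (within the scatter) and no change at the digits printed from compound 2 to compound 4 (within the scatter). Benzyl therefore groups with 3-chlorophenyl and 4-fluorophenyl rather than with methyl, and adding a phenyl to that methyl gives a 10-fold higher number from compound 3 to compound 4 (1.00 log units; beyond the scatter), so among these four compounds, all three groups with an aromatic ring stand apart from methyl. No measurement here explains this result.

Still open, as far as these compounds go, is whether the aromatic ring itself sets this gap. A cyclohexyl, an ethyl or a plain hydrogen on that nitrogen could stay level with compound 3 or with compound 4.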